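Two Thiosemicarbazones and a Halogen Swap on the Anilide Ring

This account rests on a few compounds, and the source may have more. Where it says the series, first, only, none or still open, it means among the compounds named here.

Measured so far:
compound 1 `Fc1cccc(NC(=S)N/N=C/c2ccc3ccccc3n2)c1`, 74700 nM
compound 2 `CN(C)C(=S)N/N=C/c1nc2ccccc2s1`, 250 nM

In a functional assay on HT-29 cells (Homo sapiens) for antiproliferative activity, read by sulforhodamine B assay, with a stated time of 72 h (a lower number here means a stronger inhibitor, a higher number a weaker inhibitor), compound 1 gives 74700 nM, the higher of the two numbers recorded, while compound 2 gives 250 nM, a much lower figure; the two compounds share only the thiosemicarbazone linkage and differ in both the aryl group on the nitrogen and the heteroaryl attached through the imine, so the gap between them cannot be tied to a single change.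

Compound 3 `S=C(N/N=C/c1ccc2ccccc2n1)Nc1ccc(Cl)cc1` is the next compound to be measured. It keeps the core of compound 1 and differs in one place: 4-chlorophenyl in place of 3-fluorophenyl on an amide-type nitrogen. Both the group that leaves and the group that enters are halogenated phenyl rings of the same size, and nothing in the two measured compounds speaks to what such a swap does. For compound 3 the step from compound 1 is therefore expected to be small, a 1.9-fold lower number from compound 1 to compound 3 (0.27 log units; within the scatter), likely within the scatter or slightly downward. Compound 3 is estimated at 40000 nM, between 10000 nM and 150000 nM.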

Compound 3, half-maximal inhibitory concentration: 97200 nM
Estimate against measurement, compound 3: 2.4-fold (0.39 log units) below; measured number inside the range.
By their numbers in this assay, from the lowest: compound 2; then compounds 1 and 3 (each within the scatter of the next).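

In this assay, placing 4-chlorophenyl in place of 3-fluorophenyl on an amide-type nitrogen whose other neighbour is the thiocarbonyl carbon gives a 1.3-fold higher number from compound 1 to compound 3 (0.11 log units; within the scatter), so this exchange of one halogenated phenyl ring for another does not separate the two compounds. Going by these compounds alone, this is the first step read at this position, and it shows only that changing the halogen and its numbered place together leaves the result within the scatter, with no separate contribution readable for either change. No measured evidence on these compounds bears on this result.

The compounds shown leave open what a phenyl ring carrying a carboxylic acid or an amine would do at this nitrogen, and what a longer alkyl chain in place of the ring would do. They also leave open whether the same halogen exchange would behave alike on another core.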